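Bromo to Trifluoromethyl on the Shared Core

The compounds below may be only part of what the source reports. "The series", "measured", "known", "first", "only" and "open" are said of these compounds alone.

Compound 1 `NCCn1ncc2c(NCc3ccccc3[N+](=O)[O-])cc(C(F)(F)F)cc21`: 25%
Compound 2 `O=[N+]([O-])c1cc(Cl)ccc1CNc1cc(C(F)(F)F)cc2[nH]ncc12`: 90%
Compound 3 `O=[N+]([O-])c1ccccc1CNc1cc(Br)cc2[nH]ncc12`: 52%

Of the compounds shown here, three have been measured in an assay for inhibition of Tryptophan 2,3-dioxygenase (Homo sapiens), with stated times of 10 min and 60 min, tested at 10 uM; on this read-out higher numbers stand for a stronger effect at the one concentration tested and lower numbers for a weaker effect. Compound 2 gives 90%, the highest number of the three. Compound 1 gives 25%, the lowest. Compound 3 gives 52% and stands second of the three, beyond the scatter from both neighbours: well above compound 1 and well below compound 2.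

Compound 4 `O=[N+]([O-])c1ccccc1CNc1cc(C(F)(F)F)cc2[nH]ncc12` has not yet been measured. It differs from compound 3 in one place: trifluoromethyl in place of bromo on an aromatic carbon. For the measured compounds named here, compound 2 also carries a trifluoromethyl on the shared core and gives the highest number, though it differs from compound 4 elsewhere too, so no step between measured compounds settles the question directly. Compound 1 carries the same trifluoromethyl yet gives the lowest number, again with other differences.

For compound 4, this account expects a modest rise from compound 3, near the edge of the scatter, with a step of a number 10 percentage points higher from compound 3 to compound 4 (within the scatter) in this assay. The estimate for compound 4 is 62%, in a range from 38% to 85%.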

Compound 4, a percentage reported as inhibition, at one concentration (the size of the read-out at that concentration, not a potency): 89%
Compound 4: the middle estimate sits 27 percentage points below what was measured; the whole stated range lies below it.
By their numbers in this assay, from the lowest: compound 1; then compound 3; then compounds 4 and 2 (each within the scatter of the next).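

In this assay, trifluoromethyl in place of bromo on this aromatic carbon gives a number 37 percentage points higher from compound 3 to compound 4 (beyond the scatter) and so shows that this single change on the shared core has a large effect on the read-out. Hydrogen in place of chloro on an aromatic carbon gives a number 1 percentage points lower from compound 2 to compound 4 (within the scatter) and so shows that the high number of compound 2 does not depend on its chloro. Hydrogen in place of 2-aminoethyl on an aromatic nitrogen gives a number 64 percentage points higher from compound 1 to compound 4 (beyond the scatter) and so ties the low number of compound 1 to its 2-aminoethyl and not to the trifluoromethyl it shares with compound 4.

Going by these compounds, how a methyl, a nitrile or a chloro would fare on this aromatic carbon remains open. Nothing available explains why trifluoromethyl and bromo differ so widely here.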